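This account rests on a few compounds, and the source may have more. Where it says the series, first, only, none or still open, it means among the compounds named here.

Three compounds share one core and differ only in the group attached to one aromatic carbon. Compound 1 `COc1cc2ncnc(-n3nc(-c4ccccn4)nc3N)c2cc1[N+](=O)[O-]` carries a nitro group there and gives 31100 nM in an assay on MCF7 cells for inhibition of Serine-protein kinase ATM (Homo sapiens), read by immunofluorescence, with a stated time of 1 h; a higher number here means a weaker inhibitor, a lower number a stronger inhibitor. Compound 2 `COc1cc2ncnc(-n3nc(-c4ccccn4)nc3N)c2cc1N` carries an amino group instead; in this assay compound 2 gives only a limit of the assay, > 40000 nM, and the limit of > 40000 nM in this assay, at which 1 of the 3 values shown sits, marks that limit. Compound 3 `CCN(CC)C(=O)COc1cc2c(-n3nc(-c4ccccn4)nc3N)ncnc2cc1OC` carries a (diethylcarbamoyl)methoxy group and gives 5300 nM in this assay, the lowest of the two numbers shown; the step of a 5.9-fold lower number from compound 1 to compound 3 (0.77 log units; beyond the scatter) is the nearest comparison, and an at least 7.5-fold lower number from compound 2 to compound 3 (0.87 log units; beyond the scatter) points the same way. The step of an at least 1.2-fold higher number from compound 1 to compound 2 (0.10 log units; that floor lies within the scatter) lies within the scatter.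

Compound 4 `CCCCCCOC(=O)NCCCOc1cc2c(-n3nc(-c4ccccn4)nc3N)ncnc2cc1OC` has not been measured. It differs from compound 3 by 2-((hexyloxycarbonyl)amino)ethyl in place of diethylcarbamoyl on a saturated chain carbon bound to an oxygen on an aromatic ring. Among the measured compounds shown here, both measured steps that reach compound 3 concern the exchange of a small aromatic substituent for this ether-linked chain, not the exchange of one chain end for another, so no measured step bears directly on this change. The number for compound 4 in this assay is therefore expected to stay close to that of compound 3, with a step of a 1.1-fold lower number from compound 3 to compound 4 (0.03 log units; within the scatter) and an estimate of 5000 nM, between 1500 nM and 16000 nM.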

Compound 4, half-maximal inhibitory concentration: 28600 nM
Beside the measured number, compound 4's estimate is 5.7-fold (0.76 log units) below it, and the stated range ends below it.
By their numbers in this assay, from the lowest: compound 3; then compounds 4 and 1 (each within the scatter of the next). At a limit, above all of these: compound 2.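

Until now, the steps at this position only replaced a small group on the aromatic carbon with an ether-linked chain. Compound 4 keeps the ether link and changes only the end of the chain, and in this assay this gives a 5.4-fold higher number from compound 3 to compound 4 (0.73 log units; beyond the scatter) as a change that is modest but real. The lower number of compound 3 therefore cannot be credited to the ether link alone, since the group at the end of the chain also counts, and nothing measured for these compounds says why this exchange raises the number.

The compounds shown leave open which part of 2-((hexyloxycarbonyl)amino)ethyl is responsible: the hexyl end, the carbamate or the length of the chain that carries it. On the same ether link, a methyl carbamate, a chain ending in a free amine or a carboxylic acid, and a dimethylamide in place of the diethylamide would help to separate these parts and show how much the ethyl groups of compound 3 contribute.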